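The compounds below may be only part of what the source reports. "The series", "measured", "known", "first", "only" and "open" are said of these compounds alone.

Measured in an assay for displacement of a labelled ligand from adenosine receptor A1 (Rattus norvegicus); on this read-out lower numbers stand for stronger inhibition and higher numbers for weaker inhibition:
- compound 1 `CCCC(Sc1nc(SC)c2cnn(-c3ccccc3)c2n1)C(N)=O`: 7.55 nM
- compound 2 `CCCC(Sc1nc(S)c2cnn(-c3ccccc3)c2n1)C(N)=O`: 56.3 nM
- compound 3 `CCCCC(Sc1nc(S)c2cnn(-c3ccccc3)c2n1)C(N)=O`: 37.2 nM

Compound 1 holds the lowest number of the three; compound 3 sits nearest to it and compound 2 furthest, both gaps beyond the scatter. Among the compounds with values here, the one step that changes the sulfur substituent, a 7.5-fold higher number from compound 1 to compound 2 (0.87 log units; beyond the scatter), is the only modest movement in the set. The step that alters the side chain, a 1.5-fold lower number from compound 2 to compound 3 (0.18 log units; within the scatter), stays within the scatter.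

Compound 4 `CSc1nc(SC(C(N)=O)C(C)C)nc2c1cnn2-c1ccccc1` keeps the methyl on sulfur of compound 1 and differs from it only in the side chain: isopropyl in place of propyl on a saturated chain carbon bound to a carbonyl carbon and a sulfur. The change sits on the saturated chain carbon bound to a carbonyl carbon and a sulfur, with the same atoms joined differently. Within the data shown here, the only measured step that touches this side chain, the one from compound 2 to compound 3, stayed within the scatter, so no movement beyond the scatter is expected for compound 4 in this assay, with the expected step from compound 1 being a 1.3-fold higher number from compound 1 to compound 4 (0.12 log units; within the scatter). Compound 4 is accordingly estimated at 10 nM, in the range 3.5 nM to 30 nM.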

Compound 4, inhibition constant: 15.7 nM
Beside the measured number, compound 4's estimate is 1.6-fold (0.20 log units) below it; low and high end bracket the measured number.
By their numbers in this assay, from the lowest: compound 1; then compound 4; then compounds 3 and 2 (each within the scatter of the next).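

In this assay, this position does respond to the shape of the side chain: isopropyl in place of propyl on the saturated chain carbon bound to a carbonyl carbon and a sulfur gives a 2.1-fold higher number from compound 1 to compound 4 (0.32 log units; beyond the scatter), a modest step made with no change in the atoms present. The earlier side-chain step, a 1.5-fold lower number from compound 2 to compound 3 (0.18 log units; within the scatter), gave no sign of this, but it was read with hydrogen rather than methyl on the other sulfur, so the two steps come from different backgrounds. Nothing available accounts for the step.

Still open, from the compounds shown here alone, is whether a longer chain such as pentyl, or a cyclopropyl group, would move the number further at this carbon, and whether isopropyl has the same effect with hydrogen on that sulfur. A carboxylic acid in place of the carbamoyl group also remains an open question.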